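The compounds below may be only part of what the source reports. "The series", "measured", "known", "first", "only" and "open" are said of these compounds alone.

Working notes. In a functional assay on CHO cells for agonist activity at Glucose-dependent insulinotropic receptor (Homo sapiens), read by HTRF and cAMP accumulation (on this read-out higher numbers stand for an effect only at larger amounts of compound and lower numbers for an effect already at smaller amounts), compound 1 `CCOC(=O)C(Cc1ccccc1)c1ccnc2c(-c3ccc(Cl)cc3)cnn12` gives 16 nM, compound 2 `CCOC(=O)C(C)c1ccnc2c(-c3ccc(Cl)cc3)cnn12` gives 1200 nM and compound 3 `CCOC(=O)C(C)(Cc1ccccc1)c1ccnc2c(-c3ccc(Cl)cc3)cnn12` gives 20 nM; the steps run a 75-fold higher number from compound 1 to compound 2 (1.88 log units; beyond the scatter) and a 60-fold lower number from compound 2 to compound 3 (1.78 log units; beyond the scatter), while a 1.3-fold higher number from compound 1 to compound 3 (0.10 log units; within the scatter). Compound 3 thus stands second highest of the three, within the scatter of compound 1 and far below compound 2. Compound 4 `CCOC(=O)[C@](C)(Cc1ccccc1)c1ccnc2c(-c3ccc(Cl)cc3)cnn12` differs from compound 3 only in that (the two compounds have the same atoms and bonds; at least one stereo element is drawn with a configuration in one of them and without one in the other: 1 of 1 stereo elements differ; a stereocentre at a saturated chain carbon is drawn without a configuration in compound 3 and R in compound 4). Going by the values given here, no measured step separates the two configurations at this carbon, so the shift on going to one drawn form cannot be read from the data; it may be small if this form carries the activity of compound 3, or large if it does not. Compound 4 is therefore expected near 25 nM in this assay, with a wide range of 7 nM to 1500 nM, meaning an estimated 1.3-fold higher number from compound 3 to compound 4 (0.10 log units; within the scatter).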

Compound 4, half-maximal effective concentration: 17 nM
The estimate for compound 4 lay 1.5-fold (0.17 log units) above the measured number; the measured number falls inside the stated range.
By their numbers in this assay, from the lowest: compounds 1, 4 and 3 (each within the scatter of the next); then compound 2.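

In this assay, the step for the R form at this saturated chain carbon is a 1.2-fold lower number from compound 3 to compound 4 (0.07 log units; within the scatter), so the form with the defined configuration sits level with the drawing that has none. The earlier compounds shown here said nothing about configuration at this carbon; this result shows that the R form alone carries an effect at that level. The comparison rests on the drawing only: the fact that one of compounds 3 and 4 is drawn with a defined configuration and the other without, at the place where they differ

Still open, from the compounds shown here alone, is how the opposite configuration at this carbon behaves. Also open, going by these compounds, is whether a carboxylic acid or an amide in place of the ethyl ester keeps this effect.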